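This account rests on a few compounds, and the source may have more. Where it says the series, first, only, none or still open, it means among the compounds named here.

Measured compounds in a functional assay on MCF7 cells (Homo sapiens) for antiproliferative activity, read by MTT assay, with a stated time of 24 h; on this read-out higher numbers stand for weaker inhibition and lower numbers for stronger inhibition:
- compound 1 `CCn1c(C(=O)NCC(=O)OC)ccc1C(CC)(CC)c1ccc(OCS(=O)(=O)c2ccccc2)c(C)c1` gives > 50000 nM, which is a limit of this assay and not a number.
- compound 2 `CCn1c(C(=O)NCCO)ccc1C(CC)(CC)c1ccc(OCS(=O)(=O)c2ccccc2)c(C)c1` gives 15500 nM.

On the numbers shown, compound 1 stands at the top of the range: its value is a limit, so only that it sits at the limit of > 50000 nM in this assay, at which 1 of the 2 values shown sits, is known, not where above it. For the measured compounds named here, the one measured step, an at least 3.2-fold lower number from compound 1 to compound 2 (0.50 log units; beyond the scatter), changes the same amide-type nitrogen substituent and moves the number down from the limit.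

Compound 3 `CCn1c(C(=O)N[C@H](C)C(=O)O)ccc1C(CC)(CC)c1ccc(OCS(=O)(=O)c2ccccc2)c(C)c1` is not yet measured. It differs from compound 1 in one place: 1-carboxyethyl in place of (methoxycarbonyl)methyl on an amide-type nitrogen. Going by the values given here, no measured step covers this exact change; the step from compound 1 to compound 2 bears on it only in that it alters the same group at the same place and brings a modest drop in the number. Since compound 1 itself is only a limit, the most that can be expected is a small to modest move downward, or no change beyond the scatter, with a real chance that compound 3 again reports only a limit.

Compound 3 is therefore estimated at 40000 nM, with a range of 12000 nM to 120000 nM, which corresponds to an expected step of an at least 1.2-fold lower number from compound 1 to compound 3 (0.09 log units; that floor lies within the scatter).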

Compound 3, half-maximal inhibitory concentration: > 50000 nM
Compound 3: a limit, no number; the forecaster's own chance of this, stated with the estimate: 50%; at least 1.2-fold (0.09 log units) between middle value and limit.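

In this assay compound 3 gives > 50000 nM, which is a limit of the assay and not a number, and it joins compound 1 at that same limit: the limit of > 50000 nM in this assay, at which 2 of the 3 values shown sit. The step between compound 1 and compound 3 cannot be read, as both values are limits, so this read-out shows no measurable gain from 1-carboxyethyl in place of (methoxycarbonyl)methyl on the amide-type nitrogen. Putting 1-carboxyethyl in place of 2-hydroxyethyl at the same nitrogen gives an at least 3.2-fold higher number from compound 2 to compound 3 (0.50 log units; beyond the scatter), and of the three substituents shown, only the 2-hydroxyethyl of compound 2 gives a number rather than a limit.

Compound 3 changes the ester to a carboxylic acid and also adds a branch with a defined stereocentre, so the compounds shown cannot separate these features; an unbranched carboxylic acid or the methyl ester of the branched chain would be needed to do so. Also open, going by these compounds, are how far past the limit compound 1 and compound 3 lie, and whether a longer chain ending in hydroxyl, or an amine in place of that hydroxyl, would bring the number down from that of compound 2.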